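The source may hold more compounds than are shown below. What is called first, only, known or untested is meant among the compounds shown, and "the series" means these compounds.

Compound 1 `CCCCNC(=O)COc1ccc(C(=O)c2c(CCCC)oc3ccccc23)cc1` is examined in a functional assay on HL-60 cells (Homo sapiens) for antiproliferative activity, read by MTT assay, with a stated time of 24 h; a lower number here means a stronger inhibitor, a higher number a weaker inhibitor. In this assay compound 1 returns only a limit, > 50000 nM. Compound 2 `CCCCc1oc2ccccc2c1C(=O)c1ccc(OCC(=O)N2CCOCC2)cc1` likewise returns only a limit in this assay, > 50000 nM. The step that the two limits leave unreadable from compound 1 to compound 2 therefore cannot be sized. Compound 3 `CCCCc1oc2ccccc2c1C(=O)c1ccc(OCCCC(=O)N2CCCC2)cc1` gives a readable number in this assay, 29900 nM. The steps of an at least 1.6-fold lower number from compound 1 to compound 3 (0.22 log units; that floor lies within the scatter) and an at least 1.6-fold lower number from compound 2 to compound 3 (0.22 log units; that floor lies within the scatter) both point toward a lower number, though in each case the floor lies within the scatter. Compound 1 thus stands at the limit at which two of the three values sit (the limit of > 50000 nM in this assay, at which 2 of the 3 values shown sit).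

Compound 4 `CCCCc1oc2ccccc2c1C(=O)c1ccc(OCCCC(=O)N2CCCCC2)cc1` differs from compound 1 by 2-((piperidin-1-yl)carbonyl)ethyl in place of butylcarbamoyl on a saturated chain carbon bound to an oxygen on an aromatic ring. The two measured steps that bear on this change each replaced a carbonyl-bearing group on the same saturated chain carbon with 2-((pyrrolidin-1-yl)carbonyl)ethyl and yielded a number just below the limit; the step to compound 4 is expected to behave alike. Compound 4 is therefore expected to give about 30000 nM in this assay, between 12000 nM and 60000 nM, with a fair chance of only a limit. The expected step of an at least 1.6-fold lower number from compound 1 to compound 4 (0.22 log units; that floor lies within the scatter) is thus small and downward, if readable at all.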

Compound 4, half-maximal inhibitory concentration: 31900 nM
The estimate for compound 4 lay 1.1-fold (0.03 log units) below the measured number, and the stated range covers the measured number.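

In this assay, for the compounds shown here, the change of pyrrolidin-1-yl to piperidin-1-yl on a carbonyl carbon gives a 1.1-fold higher number from compound 3 to compound 4 (0.03 log units; within the scatter), so a readable number is not confined to the single ring of compound 3. The steps of an at least 1.5-fold lower number from compound 1 to compound 4 (0.19 log units; that floor lies within the scatter) and an at least 1.5-fold lower number from compound 2 to compound 4 (0.19 log units; that floor lies within the scatter) point the same way as those to compound 3, yet their floors still establish no firm gain. Compound 1 and compound 2 remain limits, not numbers: the limit of > 50000 nM in this assay, at which 2 of the 4 values shown sit.

Each step to compound 4 changes both the chain and the amide, so the compounds shown leave open which of the two matters. Going by these compounds, a butylcarbamoyl group on the propyl chain, a (piperidin-1-yl)carbonyl group on the methyl chain, or a carboxylic acid or amine at the chain end remains untested among them.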